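Aryl swap on the indole core: methoxy to chloro

A few compounds are considered here, and "the series" means these few. Any claim that something is new, unique, unknown or untested is made for them only; others in the source may bear on it.

Measured so far:
compound 1 `COc1ccccc1N1CCN(C(=O)CCc2c(-c3ccccc3Br)[nH]c3ccc(C)cc23)CC1`: 89 nM
compound 2 `COc1ccc(-c2[nH]c3ccc(C)cc3c2CCC(=O)N2CCN(c3ccccc3OC)CC2)cc1`: 1.5 nM

In an assay on CHO cells for displacement of a labelled ligand from Substance-P receptor (Homo sapiens) (a lower number here means a stronger inhibitor, a higher number a weaker inhibitor), compound 2 gives 1.5 nM and holds the lowest number of the two measured; compound 1 gives 89 nM. Among the compounds with values here, the one step recorded, a 59-fold lower number from compound 1 to compound 2 (1.77 log units; beyond the scatter), exchanges the whole aryl group, 4-methoxyphenyl in place of 2-bromophenyl, so it does not separate the effect of the group from that of where it sits.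

Compound 3 `COc1ccccc1N1CCN(C(=O)CCc2c(-c3ccc(Cl)cc3)[nH]c3ccc(C)cc23)CC1` is not yet measured. It differs from compound 2 by chloro in place of methoxy on an aromatic carbon; cut one bond further out, the change reads 4-methoxyphenyl to 4-chlorophenyl, and the substituent stays para to a large group. Within the data shown here, no measured step isolates this swap. Among the measured compounds shown here, the only related step, a 59-fold lower number from compound 1 to compound 2 (1.77 log units; beyond the scatter), shows that what sits on this aryl ring can move this assay by a large amount, which widens the range to allow for. Because compound 2 gives 1.5 nM with the same substitution pattern, a modest weakening is expected, a 3.3-fold higher number from compound 2 to compound 3 (0.52 log units; beyond the scatter), and compound 3 is estimated at 5 nM, range 1.5 nM to 20 nM.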

Compound 3, half-maximal inhibitory concentration: 0.6 nM
Compound 3: the middle estimate sits 8.3-fold (0.92 log units) above what was measured, outside the stated range (below it).
By their numbers in this assay, from the lowest: compound 3; then compound 2; then compound 1.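

In this assay, a 2.5-fold lower number from compound 2 to compound 3 (0.40 log units; beyond the scatter) shows that the methoxy group is not needed for a low number at this place, para to a large group: chloro, with one heavy atom and no hydrogen-bond acceptor, gives a still lower number than methoxy, with two heavy atoms and one acceptor. a 150-fold lower number from compound 1 to compound 3 (2.17 log units; beyond the scatter) shows that a halogen on the aryl ring does not by itself give a low number, since compound 1 and compound 3 both carry one, yet this step changes both the kind of halogen and where it sits, so those two effects remain unseparated. The data on hand offer no explanation for either step.

Still open, going by these compounds, is how bromo would read on the carbon that holds chloro in compound 3, which would separate the kind of halogen from its place on the ring. The compounds shown also leave open whether this place accepts an amine or a carboxylic acid, and how the ring reads with hydrogen alone there.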